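Replacing 4-fluorophenyl: what happens to cell toxicity?

The source may report more compounds than this note shows. Statements on the series, on what has been measured and on what is new or still open speak of the compounds shown alone.

In an ADME assay on MRC5 cells (Homo sapiens) for cytotoxicity, read by fluorescence and resazurin assay, with a stated time of 3 days (on this read-out lower numbers stand for higher toxicity in this test and higher numbers for lower toxicity in this test), compound 2 `O=C(Nc1cc(-c2ccccn2)n[nH]1)N1CCC(c2ccc(F)cc2)CC1` gives only a limit, > 64000 nM, and not a number. Compound 1 `O=C(Nc1cc(-c2ccccn2)n[nH]1)N1CCN(c2ccc(F)cc2)CC1` also gives a limit, > 64000 nM. Compound 3 `O=C(Nc1cc(-c2ccccn2)n[nH]1)N1CCC(c2ccc(Cl)cc2)CC1` gives a limit too, > 62000 nM. Among the measured compounds shown here, the one measured step is a step that the two limits leave unreadable from compound 2 to compound 3, with chloro in place of fluoro on an aromatic carbon, and it offers no size to carry over. Compound 4 `O=C(Nc1cc(-c2ccccn2)n[nH]1)N1CCC(Oc2ccccn2)CC1` brings (pyridin-2-yl)oxy in place of 4-fluorophenyl on a saturated ring carbon. For the measured compounds named here, no measured step covers this change. The expectation therefore rests on the limit of compound 2, > 64000 nM. The expected step is a number no higher from compound 2 to compound 4 (the limit leaves the size open), which means none beyond the scatter in this assay and no favoured direction. For compound 4 the estimated value is 64000 nM, with an expected range of 30000 nM to 128000 nM.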

Compound 4, half-maximal cytotoxic concentration: > 63000 nM
Compound 4: a limit, no number; the forecaster's own chance of this, stated with the estimate: 80%; the middle value lies beyond the limit too.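

No step can be read from compound 2 or compound 3 to compound 4: in this assay all three give only limits, not numbers. The compounds shown leave open whether (pyridin-2-yl)oxy in place of 4-fluorophenyl changes cell toxicity at all.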